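The source may hold more compounds than are shown below. What is called first, only, known or untested is meant among the compounds shown, and "the series" means these compounds.

Measured so far: compound 1 `CN(C)C1CCN(C(=O)CCCOc2cc(C(=O)N3CCCCc4sccc43)ccc2NC(=O)c2ccccc2-c2ccccc2)CC1` gives 20 nM in an assay on CHO cells for inhibition of Vasopressin V2 receptor (Homo sapiens), read by radioligand binding; on this read-out higher numbers stand for weaker inhibition and lower numbers for stronger inhibition; compound 2 `CN1CCN(C(=O)CCCOc2cc(C(=O)N3CCCCc4sccc43)ccc2NC(=O)c2ccccc2-c2ccccc2)CC1` gives 6 nM; compound 3 `COc1cc(C(=O)N2CCCC(N(C)C)c3sccc32)ccc1NC(=O)c1ccccc1-c1ccccc1` gives 20 nM.

Compound 2 holds the lowest number of the three. Compound 1 and compound 3 each sit a similar distance above it, and those two show the same value as each other.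

Compound 4 `CN(C)C1CCN(C(=O)COc2cc(C(=O)N3CCCCc4sccc43)ccc2NC(=O)c2ccccc2-c2ccccc2)CC1` differs from compound 2 in (4-(dimethylamino)piperidin-1-yl)carbonyl in place of 2-((4-methylpiperazin-1-yl)carbonyl)ethyl on a saturated chain carbon bound to an oxygen on an aromatic ring. For the measured compounds named here, the one measured step that bears on this is a 3.3-fold lower number from compound 1 to compound 2 (0.52 log units; beyond the scatter), the reverse of the amine swap now made, while the shortened chain has no measured counterpart. A return toward the value of compound 1 is therefore expected, a modest rise in this assay. For compound 4 the estimate is 25 nM, within 8 nM to 80 nM, which means an expected step of a 4.2-fold higher number from compound 2 to compound 4 (0.62 log units; beyond the scatter).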

Compound 4, half-maximal inhibitory concentration: 8 nM
Estimate against measurement, compound 4: 3.1-fold (0.49 log units) above, within the range that was stated.
By their numbers in this assay, from the lowest: compounds 2 and 4 (each within the scatter of the next); then compounds 1 and 3 (each within the scatter of the next).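

In this assay, the exchange gives a 1.3-fold higher number from compound 2 to compound 4 (0.12 log units; within the scatter) on a saturated chain carbon bound to an oxygen on an aromatic ring, so ((4-(dimethylamino)piperidin-1-yl)carbonyl)methyl and 3-((4-methylpiperazin-1-yl)carbonyl)propyl read alike there. The earlier step, a 3.3-fold lower number from compound 1 to compound 2 (0.52 log units; beyond the scatter) with the chain unchanged, exchanged the amine alone, whereas here amine and chain change together and the step stays within the scatter. No evidence available explains this result. The compounds shown leave open how ((4-methylpiperazin-1-yl)carbonyl)methyl would read at this place, and whether a carboxylic acid there would hold the value.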